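This account rests on a few compounds, and the source may have more. Where it says the series, first, only, none or still open, it means among the compounds named here.

In a functional assay on HepG2 cells (Homo sapiens) for antiproliferative activity, read by CCK-8 assay, with a stated time of 48 h (on this read-out lower numbers stand for stronger inhibition and higher numbers for weaker inhibition), the three measured compounds stand as follows:
compound 1 `CNC(=O)c1cc(Oc2ccc(/C=C/c3ccccn3)cc2)ccn1` gives 21600 nM;
compound 2 `O=C(c1cc(Oc2ccc(/C=C/c3ccccn3)cc2)ccn1)N1CCCC1` gives 27000 nM;
compound 3 `CNC(=O)c1cc(Oc2ccc(/C=C/c3ccncc3)cc2)ccn1` gives 18200 nM.

Compound 3 holds the lowest of these three numbers, yet its gaps to compound 1 and to compound 2 both lie within the usual scatter, so no real separation is shown. Compound 4 `O=C(NCc1ccccc1)c1cc(Oc2ccc(/C=C/c3ccncc3)cc2)ccn1` differs from compound 3 by phenyl in place of hydrogen on a saturated chain carbon bound to an amide-type nitrogen. Among the compounds with values here, one measured step touches the same region, the group on the carbonyl carbon: a 1.3-fold higher number from compound 1 to compound 2 (0.10 log units; within the scatter), which stayed within the scatter. The other step, a 1.2-fold lower number from compound 1 to compound 3 (0.07 log units; within the scatter), was also small. A change at the amide-type nitrogen is therefore expected to give a 1.0-fold lower number from compound 3 to compound 4 (0.00 log units; within the scatter), nothing beyond the scatter. Compound 4 is estimated at 18000 nM, within 7000 nM to 45000 nM.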

Compound 4, half-maximal inhibitory concentration: 28900 nM
Compound 4: middle estimate off by 1.6-fold (0.21 log units), on the low side, and the stated range covers the measured number.
By their numbers in this assay, from the lowest: compounds 3, 1, 2 and 4 (each within the scatter of the next).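

Replacing methyl with benzyl on the amide-type nitrogen gives a 1.6-fold higher number from compound 3 to compound 4 (0.20 log units; within the scatter). This shows that the position can carry a whole added phenyl ring with no change beyond the scatter, a much larger addition than the earlier swap of methylamino for pyrrolidin-1-yl at the same carbonyl carbon. Nothing available explains this result.

On these data alone, it remains open whether an amine or a carboxylic acid on the added phenyl ring would move the number beyond the scatter. A longer chain between that ring and the amide-type nitrogen is equally untested here.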